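Trifluoromethyl for methyl on a weak triazole series

This account rests on a few compounds, and the source may have more. Where it says the series, first, only, none or still open, it means among the compounds named here.

Among the measured compounds shown here, compound 2 `Cc1ccc(-c2cn(Cc3ccccc3)nn2)cc1` gives 129000 nM in a functional assay on NUGC-3 cells (Homo sapiens) for antiproliferative activity, read by MTT assay, with a stated time of 72 h (a higher number here means a weaker inhibitor, a lower number a stronger inhibitor), the lowest of the two numbers so far, though within the scatter of compound 1 `COc1ccc(-c2cn(Cc3ccccc3)nn2)cc1`, which gives 158000 nM in this assay. Compound 3 `FC(F)(F)c1ccc(-c2cn(Cc3ccccc3)nn2)cc1` differs from compound 2 by trifluoromethyl in place of methyl on an aromatic carbon. For the measured compounds named here, the only comparable step, a 1.2-fold lower number from compound 1 to compound 2 (0.09 log units; within the scatter), also swapped the group at this position and stayed within the scatter. For compound 3 the expected change is therefore small, a 1.3-fold lower number from compound 2 to compound 3 (0.11 log units; within the scatter), with no direction beyond the scatter. Compound 3 is estimated at 100000 nM in this assay, ranging from 40000 nM to 250000 nM.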

Compound 3, half-maximal inhibitory concentration: 81000 nM
The estimate for compound 3 lay 1.2-fold (0.09 log units) above the measured number, within the range that was stated.
By their numbers in this assay, from the lowest: compounds 3, 2 and 1 (each within the scatter of the next).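

With trifluoromethyl in place of methyl on this aromatic carbon, this assay shows a 1.6-fold lower number from compound 2 to compound 3 (0.20 log units; within the scatter) even though the group grows from 1 heavy atom to 4 heavy atoms. Against the methoxy group, the step is a 2.0-fold lower number from compound 1 to compound 3 (0.29 log units; within the scatter) and so also stays inside the normal noise, leaving all three groups indistinguishable at this position. No evidence here explains this flat result. On these data alone, whether an amine, a carboxylic acid or a longer chain at this position would move the number beyond the scatter remains open, as does the effect of changes elsewhere on the shared core.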